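A few compounds are considered here, and "the series" means these few. Any claim that something is new, unique, unknown or untested is made for them only; others in the source may bear on it.

Compound 1, `COc1cc2ncnc(NNC(=S)NC(=O)c3ccc(C(F)(F)F)cc3)c2cc1OC`, gives 16800 nM in a functional assay on MCF7 cells (Homo sapiens) for cytotoxicity, read by MTT assay, with a stated time of 72 h; on this read-out higher numbers stand for weaker inhibition and lower numbers for stronger inhibition.
Compound 2, `COc1cc2ncnc(NNC(=S)NC(=O)c3ccccc3Cl)c2cc1OC`, gives 23100 nM in this assay.

The unmeasured compound 3, `COc1cc2ncnc(NNC(=S)NC(=O)c3ccccc3OC)c2cc1OC`, shares the core of compound 2 and differs from it in one place: methoxy in place of chloro on an aromatic carbon. Going by the values given here, on the two numbers so far, compound 2 carries the highest value, with compound 1 as its only neighbour, and the single measured step, a 1.4-fold higher number from compound 1 to compound 2 (0.14 log units; within the scatter), lies within the scatter, so the exchange of one aryl group on the carbonyl carbon for another has left the read-out essentially unmoved. Among the compounds with values here, no measured pair exchanges a methoxy for a chloro, so the step to compound 3 rests on that one comparison alone. Given that the only available step stayed within the scatter, the change to compound 3 is expected to produce no step beyond the scatter either, in either direction; the estimated step is a 1.1-fold lower number from compound 2 to compound 3 (0.02 log units; within the scatter). For compound 3 in this assay the estimate is therefore 22000 nM, with a range from 9000 nM to 55000 nM.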

Compound 3, half-maximal inhibitory concentration: 8800 nM
The estimate for compound 3 lay 2.5-fold (0.40 log units) above the measured number; the measured number lies below the stated range.
By their numbers in this assay, from the lowest: compounds 3, 1 and 2 (each within the scatter of the next, the first and the last beyond it).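

In this assay, methoxy in place of chloro on an aromatic carbon ortho to a large group gives a 2.6-fold lower number from compound 2 to compound 3 (0.42 log units; beyond the scatter), the first step among these compounds to lie beyond the scatter, so a change at this one position can register on the read-out, which the earlier exchange of whole aryl groups did not show. The reach of this step is limited, however: 2-methoxyphenyl in place of 4-(trifluoromethyl)phenyl gives a 1.9-fold lower number from compound 1 to compound 3 (0.28 log units; within the scatter), which stays within the scatter, so compound 3 is separated from compound 2 but not from compound 1. No supporting data accompany these numbers to account for the step.

The compounds shown leave open whether the step is particular to methoxy or would recur with an ethoxy, a hydroxyl or an amine on the same aromatic carbon. They also leave open how a longer chain such as propoxy would read at this position, and whether the step from chloro to methoxy would keep its size with any other group on the rest of the molecule.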